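The source may hold more compounds than are shown below. What is called first, only, known or untested is meant among the compounds shown, and "the series" means these compounds.

Measured so far in an ADME assay on microsomes from liver (Homo sapiens) for metabolic stability, read by LC-MS, using NADPH, with stated times of 5 min and 30 min, tested at 1 uM; on this read-out higher numbers stand for a more stable compound and lower numbers for a less stable compound:
compound 1 `COc1cccc(S(=O)(=O)/C=C/c2ccccn2)c1` gives 74% as its reading
compound 2 `COc1cccc(S(=O)(=O)/C=C/c2cccc(Cl)n2)c1` gives 34% as its reading
compound 3 `COc1cccc(S(=O)(=O)/C=C/c2ccc(Cl)cn2)c1` gives 9.6% as its reading

Of these three, compound 1 stands highest, and compound 2 is its nearest neighbour on the numbers. The compound still to be measured, compound 4 `COc1cccc(S(=O)(=O)/C=C/c2ncccc2Cl)c1`, keeps the core of compound 1 and carries one change: chloro in place of hydrogen on an aromatic carbon. In words, this is chloro in place of hydrogen on an aromatic carbon, here ortho to a large group and two atoms from the ring nitrogen.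

For the measured compounds named here, two measured steps bear on it, as both are the same kind of replacement made on other aromatic carbons of that ring. The first is a number 40 percentage points lower from compound 1 to compound 2 (beyond the scatter) and the second is a number 64.4 percentage points lower from compound 1 to compound 3 (beyond the scatter), and both are large and go the same way. Neither compound 2 nor compound 3 carries the chloro at the place it occupies in compound 4, so these steps guide the direction more firmly than the size. On the strength of these two steps, a clear fall in this assay is expected, and the expected step is a number 38 percentage points lower from compound 1 to compound 4 (beyond the scatter) in size. Compound 4 is therefore estimated to read 36% with an expected range of 12% to 62% when its measurement arrives.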

Compound 4, percent of the compound remaining: 22%
The estimate for compound 4 lay 14 percentage points above the measured number, within the range that was stated.
By their numbers in this assay, from the lowest: compound 3; then compound 4; then compound 2; then compound 1.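

In this assay, for the compounds shown here, chloro in place of hydrogen on an aromatic carbon, here ortho to a large group and two atoms from the ring nitrogen, gives a number 52 percentage points lower from compound 1 to compound 4 (beyond the scatter), so this position does not escape the fall that the earlier compounds showed on other carbons of the same ring. Set beside a number 40 percentage points lower from compound 1 to compound 2 (beyond the scatter) and a number 64.4 percentage points lower from compound 1 to compound 3 (beyond the scatter), this makes three placements of chloro on that ring, and each one reads lower than compound 1, with no compound shown going against that direction. Nothing shown here explains why the replacement lowers the reading at this position.

At this position the compounds shown hold only hydrogen and chloro, which leaves open how fluoro, a methyl group, a methoxy group or an amine would read there, and whether any of them would stay closer to compound 1 at 74%. They also leave open whether the fall belongs to chloro in particular or would follow any replacement of hydrogen on this ring.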